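Swapping the aryl group of a weak cinnamamide analogue

The source may report more compounds than this note shows. Statements on the series, on what has been measured and on what is new or still open speak of the compounds shown alone.

Measured compounds:
Compound 1, `COc1ccc(C(=O)c2cc(OC)c(OC)c(OC)c2)cc1NC(=O)/C=C/c1ccc(F)cc1`: 60 nM in a functional assay on HeLa cells (Homo sapiens) for cytotoxicity, read by MTT assay, with a stated time of 72 h; on this read-out lower numbers stand for stronger inhibition and higher numbers for weaker inhibition
Compound 2, `C#CCOc1cccc(/C=C/C(=O)Nc2cc(C(=O)c3cc(OC)c(OC)c(OC)c3)cc(OC)c2OC)c1`: 7300 nM in this assay

Among the compounds with values here, only two compounds have been measured, and no pair among them differs in a single place. Compound 2 gives the higher of the two numbers in this assay, and its nearest neighbour, compound 1, gives a far lower number, a gap well beyond the scatter. Compound 1 differs from compound 2 both in its core and in the aryl group on the double-bonded chain, so the two values alone cannot say which change carries the gap.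

Compound 3, `COc1cc(C(=O)c2cc(OC)c(OC)c(OC)c2)cc(NC(=O)/C=C/c2ccc(F)cc2)c1OC`, keeps the core of compound 2 and carries the aryl group of compound 1: 4-fluorophenyl in place of 3-(propargyloxy)phenyl on a double-bonded chain carbon bound to a double-bonded chain carbon. Because compound 1 gives 60 nM with this same aryl group, compound 3 is expected to give a lower number than compound 2, but since the core of compound 3 is that of compound 2, the expected step from compound 2 to compound 3 is a 7.3-fold lower number from compound 2 to compound 3 (0.86 log units; beyond the scatter), with wide uncertainty. Compound 3 is therefore estimated at 1000 nM, within a range from 120 nM to 8000 nM.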

Compound 3, half-maximal inhibitory concentration: 900 nM
Estimate against measurement, compound 3: 1.1-fold (0.05 log units) above; the measured number falls inside the stated range.
By their numbers in this assay, from the lowest: compound 1; then compound 3; then compound 2.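

In this assay, 4-fluorophenyl in place of 3-(propargyloxy)phenyl on a double-bonded chain carbon bound to a double-bonded chain carbon gives an 8.1-fold lower number from compound 2 to compound 3 (0.91 log units; beyond the scatter), which shows that the aryl group at this place matters on the core of compound 2. Compound 3 also links the two earlier compounds, because it differs from compound 1 in a single place: methoxy in place of hydrogen on an aromatic carbon gives a 15-fold higher number from compound 1 to compound 3 (1.18 log units; beyond the scatter), so each of the two single changes on its own moves the number beyond the scatter. Nothing measured here explains why either change has this result.

The swap leaves open whether the lower number of compound 3 comes from losing 3-(propargyloxy)phenyl or from gaining 4-fluorophenyl, a question that a plain phenyl group at this place could help to separate. Going by these compounds, it also remains open whether the aryl swap would have a step of similar size on the core of compound 1, and whether a hydroxy or ethoxy group in place of the added methoxy would behave like methoxy or like hydrogen.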